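Terminal amide variation on the shared core: compound 3

The source may report more compounds than this note shows. Statements on the series, on what has been measured and on what is new or still open speak of the compounds shown alone.

Measured compounds in an assay on HEK293 cells for displacement of a labelled ligand from NPC1-like intracellular cholesterol transporter 1 (Homo sapiens); on this read-out lower numbers stand for stronger inhibition and higher numbers for weaker inhibition:
- compound 1 `O=C(CN1CN(c2ccccc2)C2(CCN(C(=O)c3ccc(C4CCCCC4)cc3)CC2)C1=O)NCCO` gives 2000 nM
- compound 2 `CC(C)(C)OC(=O)NCNC(=O)CN1CN(c2ccccc2)C2(CCN(C(=O)c3ccc(C4CCCCC4)cc3)CC2)C1=O` gives 1700 nM

Within the data shown here, compound 2 has the lower of the two numbers, but it sits within the scatter of compound 1: the one measured step, a 1.2-fold lower number from compound 1 to compound 2 (0.07 log units; within the scatter), shows that exchanging the outer part of the side chain on the same amide-type nitrogen leaves the read-out essentially unchanged. No ordering of the two measured compounds can be claimed.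

Compound 3 `CS(=O)(=O)N1CCN(C(=O)CN2CN(c3ccccc3)C3(CCN(C(=O)c4ccc(C5CCCCC5)cc4)CC3)C2=O)CC1` carries the change (4-(methylsulfonyl)piperazin-1-yl in place of (((tert-butoxycarbonyl)amino)methyl)amino on a carbonyl carbon). Among the measured compounds shown here, the exchange sits at the same end of the molecule as the step from compound 1 to compound 2, and that step is the only comparison bearing on it; it was within the scatter. The present change is larger in kind, since both hydrogen-bond donors of the leaving group are lost and a six-membered ring enters, but nothing in the measured pair ties donors at this position to the read-out. The expectation is therefore a step of about a 1.1-fold higher number from compound 2 to compound 3 (0.02 log units; within the scatter), with the outcome most likely again within the scatter of compound 2. For compound 3 the estimate in this assay is 1800 nM, expected to lie between 700 nM and 4500 nM.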

Compound 3, half-maximal inhibitory concentration: 6300 nM
The estimate for compound 3 lay 3.5-fold (0.54 log units) below the measured number; measured number above the stated range.
By their numbers in this assay, from the lowest: compounds 2 and 1 (each within the scatter of the next); then compound 3.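

In this assay this end of the molecule proves sensitive to the group on the carbonyl carbon: 4-(methylsulfonyl)piperazin-1-yl in place of (((tert-butoxycarbonyl)amino)methyl)amino gives a 3.7-fold higher number from compound 2 to compound 3 (0.57 log units; beyond the scatter), and in place of (2-hydroxyethyl)amino it gives a 3.2-fold higher number from compound 1 to compound 3 (0.50 log units; beyond the scatter). The earlier pair showed no separation between two open-chain groups, whereas both steps to the ring-bearing group lie beyond the scatter and are modest in size, so the position is not indifferent to every exchange. No measurement is available that accounts for the loss in compound 3.

The exchange from compound 2 to compound 3 brings in a six-membered ring and a methylsulfonyl group while going from 2 hydrogen-bond donors to 0, and the compounds shown leave open which of these changes carries the step. A piperidin-1-yl group, a 4-acetylpiperazin-1-yl group and a dimethylamino group on the same carbonyl carbon would separate the ring, the methylsulfonyl group and the loss of the amide hydrogen.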